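Shortening the chain on the ring nitrogen of compound 3

This account rests on a few compounds, and the source may have more. Where it says the series, first, only, none or still open, it means among the compounds named here.

Three compounds share one core and differ at two places. Compound 1 `CC(C)(C)Cn1cc2c(Cl)nc(NC(=O)c3ccccc3)nc2n1` gives 30300 nM in an assay on CHO cells for displacement of a labelled ligand from adenosine receptor A3 (Homo sapiens), read by scintillation counting, with a stated time of 3 h; a lower number here means a stronger inhibitor, a higher number a weaker inhibitor. Compound 2 `Cn1cc2c(Cl)nc(NC(=O)c3ccc(C(F)(F)F)cc3)nc2n1` gives 33500 nM in this assay, and compound 3 `CC(C)(C)Cn1cc2c(Cl)nc(NC(=O)c3ccc(C(F)(F)F)cc3)nc2n1` gives 6600 nM, the lowest of the three numbers, with both others beyond the scatter above it. The step of a 4.6-fold lower number from compound 1 to compound 3 (0.66 log units; beyond the scatter) and the step of a 5.1-fold lower number from compound 2 to compound 3 (0.71 log units; beyond the scatter) show what each of the two changes contributed.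

Compound 4 `CC(C)n1cc2c(Cl)nc(NC(=O)c3ccc(C(F)(F)F)cc3)nc2n1` takes the next step: isopropyl in place of neopentyl on an aromatic nitrogen. Among the compounds with values here, of the measured steps, only the one from compound 2 to compound 3 touches this position, where a larger group on the ring nitrogen lowered the number. Isopropyl sits between methyl and neopentyl in size, so the expectation is a number for compound 4 somewhat higher than for compound 3, but not back to the level of compound 2. For compound 4 the step expected is a 2.3-fold higher number from compound 3 to compound 4 (0.36 log units; beyond the scatter). Compound 4 is therefore estimated at 15000 nM in this assay, within a range from 6000 nM to 40000 nM.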

Compound 4, inhibition constant: 10300 nM
Beside the measured number, compound 4's estimate is 1.5-fold (0.16 log units) above it, and the stated range covers the measured number.
By their numbers in this assay, from the lowest: compounds 3 and 4 (each within the scatter of the next); then compounds 1 and 2 (each within the scatter of the next).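

Isopropyl in place of neopentyl gives a 1.6-fold higher number from compound 3 to compound 4 (0.19 log units; within the scatter) so in this assay these two groups on the aromatic nitrogen cannot be told apart. Isopropyl in place of methyl gives a 3.3-fold lower number from compound 2 to compound 4 (0.51 log units; beyond the scatter) so the three carbons of isopropyl are already enough for a real difference from methyl, and the longer neopentyl adds nothing that can be read beyond the scatter. Nothing available explains why the number responds to this group on the ring nitrogen.

From the compounds shown here alone, what remains open is whether an ethyl group, a cyclopropyl ring or a chain ending in an amine on this nitrogen would keep the number at this level or take it lower. Also open, going by these compounds, is how isopropyl behaves when the trifluoromethyl group on the aromatic ring is replaced by hydrogen.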